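A few compounds are considered here, and "the series" means these few. Any claim that something is new, unique, unknown or untested is made for them only; others in the source may bear on it.

Measured compounds in a functional assay on SK-OV-3 cells (Homo sapiens) for cytotoxicity; a lower number here means a stronger inhibitor, a higher number a weaker inhibitor:
compound 1 `Cc1nn(C)c(-n2cccc2)c1/C=N/OCc1ccc(C(=O)OC(C)(C)C)cc1` gives 3.91 ug/mL;
compound 2 `Cc1nn(C)c(Oc2ccc(Cl)cc2)c1/C=N/OCc1ccc(C(=O)OC(C)(C)C)cc1` gives 0.28 ug/mL;
compound 3 `Cc1nn(C)c(-n2cccn2)c1/C=N/OCc1ccc(C(=O)OC(C)(C)C)cc1` gives 9.63 ug/mL.

Compound 3 stands at the highest number of the three: a 2.5-fold higher number from compound 1 to compound 3 (0.39 log units; beyond the scatter) and a 34-fold higher number from compound 2 to compound 3 (1.54 log units; beyond the scatter). Compound 4 `Cc1nn(C)c(Sc2ccccc2)c1/C=N/OCc1ccc(C(=O)OC(C)(C)C)cc1` is not yet measured. It differs from compound 3 in one place: phenylsulfanyl in place of 1H-pyrazol-1-yl on an aromatic carbon. The step that bears most on this is the one that put a six-membered carbon ring through a single linking atom in place of a small five-membered ring: a 34-fold higher number from compound 2 to compound 3 (1.54 log units; beyond the scatter). Compound 4 carries such a ring again, though without the chlorine of compound 2, so a large step downward in this assay is expected, a 16-fold lower number from compound 3 to compound 4 (1.21 log units; beyond the scatter). Compound 4 is therefore estimated at 0.6 ug/mL, within 0.15 ug/mL to 2.5 ug/mL.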

Compound 4, half-maximal inhibitory concentration: 0.92 ug/mL
Beside the measured number, compound 4's estimate is 1.5-fold (0.19 log units) below it; the measured number falls inside the stated range.
By their numbers in this assay, from the lowest: compound 2; then compound 4; then compound 1; then compound 3.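

In this assay, phenylsulfanyl on this aromatic carbon gives a large drop from 1H-pyrazol-1-yl (a 10-fold lower number from compound 3 to compound 4 (1.02 log units; beyond the scatter)) and a modest one from 1H-pyrrol-1-yl (a 4.3-fold lower number from compound 1 to compound 4 (0.63 log units; beyond the scatter)). A six-membered carbon ring held through a single linking atom thus gives lower numbers than either five-membered ring in both compound 2 and compound 4, though compound 4 does not reach 4-chlorophenoxy (a 3.3-fold higher number from compound 2 to compound 4 (0.52 log units; beyond the scatter)). Nothing measured here accounts for these differences. That last step changes the linking atom and the chlorine together, so neither can be judged alone. Going by these compounds, how an amine would behave at this position also remains open.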